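A few compounds are considered here, and "the series" means these few. Any claim that something is new, unique, unknown or untested is made for them only; others in the source may bear on it.

Of the compounds shown here, three with the same core have been tested in a functional assay on MDA-MB-231 cells (Homo sapiens) for cytotoxicity, read by MTT assay, with a stated time of 72 h; a lower number here means a stronger inhibitor, a higher number a weaker inhibitor: compound 1 (`CC1CCN(Cc2ccc3nc(NC(=O)N/N=C/c4cn(Cc5ccc(Cl)cc5Cl)c5ccccc45)sc3c2)CC1`) gives 3140 nM, compound 2 (`CC1CCN(Cc2ccc3nc(NC(=O)N/N=C/c4cn(Cc5cccc(Cl)c5)c5ccccc45)sc3c2)CC1`) gives 2110 nM, and compound 3 (`CC1CCN(Cc2ccc3nc(NC(=O)N/N=C/c4cn(Cc5ccc(Cl)cc5)c5ccccc45)sc3c2)CC1`) gives 2850 nM. Compound 3 cannot be told apart from the other two, as the steps to it show: a 1.1-fold lower number from compound 1 to compound 3 (0.04 log units; within the scatter), and a 1.4-fold higher number from compound 2 to compound 3 (0.13 log units; within the scatter).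

Compound 4 (`CC1CCN(Cc2ccc3nc(NC(=O)N/N=C/c4cn(Cc5ccc(C(C)(C)C)cc5)c5ccccc45)sc3c2)CC1`) keeps everything in compound 3 except one group, with tert-butyl in place of chloro on an aromatic carbon. The nearest evidence comes from the changes on this same ring. Besides the two steps above, there is a 1.5-fold lower number from compound 1 to compound 2 (0.17 log units; within the scatter). All three stay within the scatter, but each only moves or removes a chloro group. None shows what a larger tert-butyl group does, so any forecast is an extrapolation and needs a wide range.

In this assay, no step beyond the scatter is expected, and no direction can be favoured. The expected step is a 1.0-fold lower number from compound 3 to compound 4 (0.01 log units; within the scatter). Compound 4 is estimated at 2800 nM, with an expected range from 1300 nM to 6000 nM.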

Compound 4, half-maximal inhibitory concentration: 3880 nM
For compound 4 the middle estimate is 1.4-fold (0.14 log units) below the measured one; the measured number falls inside the stated range.
By their numbers in this assay, from the lowest: compounds 2, 3, 1 and 4 (each within the scatter of the next).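

In this assay, the swap of chloro for tert-butyl, with 4 heavy atoms entering where 1 leaves, stays within the scatter (a 1.4-fold higher number from compound 3 to compound 4 (0.13 log units; within the scatter)). This position therefore accepts an all-carbon group with more heavy atoms and shows no measurable change, something the chloro moves and removals could not show. The comparisons with the other two chlorinated compounds also stay within the scatter (a 1.8-fold higher number from compound 2 to compound 4 (0.26 log units; within the scatter); a 1.2-fold higher number from compound 1 to compound 4 (0.09 log units; within the scatter)), and no accompanying measurement helps to interpret this result.

As far as these compounds go, only chloro and tert-butyl appear on this ring, so it remains open whether an amine, a carboxylic acid or a longer chain at the same place would give a step beyond the scatter. From the compounds shown here alone, the rest of the shared core is identical in all four compounds, so the effect of changes there also remains open.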